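The source may hold more compounds than are shown below. What is called first, only, known or untested is meant among the compounds shown, and "the series" means these compounds.

Going by the values given here, with compound 1 (`COc1ccc(CN2C(=O)C(=O)c3cc(-c4cccc(OC)c4)ccc32)cc1`) at 100 nM as the only other number, compound 2 (`COc1ccc(CN2C(=O)C(=O)c3cc(-c4ccc(C(F)(F)F)cc4)ccc32)cc1`) at 350 nM stands highest in a functional assay on K562 cells (Homo sapiens) for antiproliferative activity, read by MTT assay, with a stated time of 48 h (a lower number here means a stronger inhibitor, a higher number a weaker inhibitor), so far. Compound 3 (`COc1ccc(CN2C(=O)C(=O)c3cc(-c4ccncc4)ccc32)cc1`) differs from compound 2 by pyridin-4-yl in place of 4-(trifluoromethyl)phenyl on an aromatic carbon with pyridin-4-yl in place of 4-(trifluoromethyl)phenyl on an aromatic carbon. Among the compounds with values here, the one measured step on that carbon is a 3.5-fold higher number from compound 1 to compound 2 (0.54 log units; beyond the scatter) and it is modest, so a step of similar or smaller size is expected in this assay for this change. The expected move is toward a lower number, a 1.4-fold lower number from compound 2 to compound 3 (0.15 log units; within the scatter) as estimated. For compound 3 the estimated value is 250 nM with 80 nM to 800 nM as the expected range.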

Compound 3, half-maximal inhibitory concentration: 40 nM
The estimate for compound 3 lay 6.3-fold (0.80 log units) above the measured number; measured number below the stated range.
By their numbers in this assay, from the lowest: compound 3; then compound 1; then compound 2.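

In this assay, going by these compounds alone, pyridin-4-yl on this aromatic carbon gives an 8.8-fold lower number from compound 2 to compound 3 (0.94 log units; beyond the scatter), a larger step than the one earlier change at this position and in the opposite direction. Against 3-methoxyphenyl it gives a 2.5-fold lower number from compound 1 to compound 3 (0.40 log units; beyond the scatter), so compound 3 holds the lowest number of the three and a ring of carbon only is not needed here. Nothing on hand bears on the reason for these steps.

Still open, on these data alone, is whether pyridin-3-yl would match pyridin-4-yl. As far as these compounds go, the effect of a morpholine or a carboxylic acid at this carbon also remains open.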